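Swapping Methyl for Chloro on the Benzyloxy Ring

The source may hold more compounds than are shown below. What is called first, only, known or untested is meant among the compounds shown, and "the series" means these compounds.

Within the data shown here, compound 2 `Cc1ccccc1COc1ccc(-c2cc(CN3CCN(Cc4ccc(C(F)(F)F)cc4)CC3)no2)cc1` carries the smaller of the two numbers measured so far in a functional assay on Mahlavu cells (Homo sapiens) for antiproliferative activity, read by sulforhodamine B assay, with a stated time of 72 h (on this read-out higher numbers stand for weaker inhibition and lower numbers for stronger inhibition), where compound 2 gives 6800 nM. Among the measured compounds shown here, its only neighbour is compound 1 `FC(F)(F)c1ccc(CN2CCN(Cc3cc(-c4ccc(OCc5ccccc5)cc4)on3)CC2)cc1`, which in this assay gives 11700 nM, a gap that stays within the scatter. Compound 3 `FC(F)(F)c1ccc(CN2CCN(Cc3cc(-c4ccc(OCc5ccccc5Cl)cc4)on3)CC2)cc1` differs from compound 2 by chloro in place of methyl on an aromatic carbon. Just one measured step bears on this part of the molecule, a 1.7-fold lower number from compound 1 to compound 2 (0.24 log units; within the scatter), and it was too small to count as a real change. For the measured compounds named here, no measured compound yet shows how a chloro behaves in this place, so the expectation can only be that the number stays close to that of compound 2, with no shift beyond the scatter. Compound 3 is therefore estimated to give 6000 nM in this assay, with a range from 2500 nM to 15000 nM. The expected step of a 1.1-fold lower number from compound 2 to compound 3 (0.05 log units; within the scatter) is small.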

Compound 3, half-maximal inhibitory concentration: 3200 nM
Compound 3: the middle estimate sits 1.9-fold (0.27 log units) above what was measured, within the range that was stated.
By their numbers in this assay, from the lowest: compound 3; then compounds 2 and 1 (each within the scatter of the next).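

Going from 2-methylbenzyl to 2-chlorobenzyl gives a 2.1-fold lower number from compound 2 to compound 3 (0.33 log units; beyond the scatter) in this assay, so this position does respond to what is placed on it, even when one heavy atom simply replaces another. Measured against the ring without a substituent, chloro in place of hydrogen gives a 3.7-fold lower number from compound 1 to compound 3 (0.56 log units; beyond the scatter) and so passes beyond the scatter, which the methyl step from the same starting point did not do. Compound 3 therefore has the lowest number of the three, although both of its steps are modest. Nothing available explains why chloro and methyl differ here. As far as these compounds go, whether fluoro, methoxy or a nitrile at this place would lower the number further remains open, as does whether chloro would give the same result on another carbon of this ring.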